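The source may hold more compounds than are shown below. What is called first, only, known or untested is meant among the compounds shown, and "the series" means these compounds.

Compound 1 `Clc1ccccc1Cn1nnc2c(NC3CCCC3)ncnc21` gives 21 nM in an assay on cell membranes for binding affinity to adenosine receptor A1 (Bos taurus), read by radioligand binding; on this read-out lower numbers stand for stronger inhibition and higher numbers for weaker inhibition. Compound 2 `CC1CCCC(Nc2ncnc3c2nnn3Cc2ccccc2Cl)C1` gives 102 nM in this assay. Compound 3 `O=[N+]([O-])c1cccc(Nc2ncnc3c2nnn3Cc2ccccc2Cl)c1` gives 3300 nM in this assay.

Among the three, compound 3 gives the highest number in this assay: the step of a 32-fold higher number from compound 2 to compound 3 (1.51 log units; beyond the scatter) and the step of a 160-fold higher number from compound 1 to compound 3 (2.20 log units; beyond the scatter) both lie beyond the scatter, so compound 3 is the weakest of the measured set. The step of a 4.9-fold higher number from compound 1 to compound 2 (0.69 log units; beyond the scatter) is smaller but also beyond the scatter.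

Compound 4 `Nc1ccc(Nc2ncnc3c2nnn3Cc2ccccc2Cl)cc1` has not yet been measured. It differs from compound 3 in one place: 4-aminophenyl in place of 3-nitrophenyl on a nitrogen on an aromatic ring. Among the measured compounds shown here, none of the measured steps compares two such groups with each other; every one of them sets a cycloalkyl against another cycloalkyl or against the 3-nitrophenyl group. The steps from compound 1 and compound 2 to compound 3 only show that the 3-nitrophenyl group sits far below the cycloalkyl groups. On that footing the exchange for 4-aminophenyl is expected to move the number in this assay by no more than a modest amount, with no firm direction, as a 1.3-fold lower number from compound 3 to compound 4 (0.12 log units; within the scatter). Compound 4 is therefore estimated at 2500 nM, expected to fall between 500 nM and 12000 nM.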

Compound 4, inhibition constant: > 1000 nM
Compound 4 gave a limit, no number; the forecaster's own chance of this, stated with the estimate: 10%; the middle value is on the limit's open side.
By their numbers in this assay, from the lowest: compound 1; then compound 2; then compound 3.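

The result for compound 4 in this assay is a limit and not a number: the limit of > 1000 nM in this assay, at which 1 of the 4 values shown sits.

Even so, its steps from the two cycloalkyl compounds can be read: 4-aminophenyl in place of 3-methylcyclohexyl gives an at least 9.8-fold higher number from compound 2 to compound 4 (0.99 log units; beyond the scatter), and 4-aminophenyl in place of cyclopentyl gives an at least 47-fold higher number from compound 1 to compound 4 (1.67 log units; beyond the scatter). The earlier compounds had shown such a large loss against the cycloalkyl groups for the 3-nitrophenyl group alone, and now a second substituted phenyl group on this nitrogen also lies on the weak side of both, so the loss is not confined to the nitro compound. The step between compound 3 and compound 4 cannot be read, and the two substituted phenyl groups therefore cannot be placed in any order.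

The compounds shown leave open whether an unsubstituted phenyl group on this nitrogen would stand with the cycloalkyl compounds or with compound 3 and compound 4, which would tell whether the phenyl ring itself or its substituents go with the weaker binding. They also leave open how a 3-aminophenyl or a 4-nitrophenyl group would compare, since the nitro and amino groups here differ in where they sit on the ring as well as in what they are.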